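The source may hold more compounds than are shown below. What is called first, only, known or untested is meant among the compounds shown, and "the series" means these compounds.

Series values in a functional assay on the whole organism (strain Wistar) for inhibition, with Rattus norvegicus as the target, read by paw edema, with stated times of 60 min and 3 h, at a dose of 100 mg/kg by the oral route; a lower number here means less inhibition, a higher number more inhibition at the dose given (going by the name of the read-out):

Compound 1 `CCNC(=O)CC1CCc2cc(OC)c(OC)cc21`: 26.1%
Compound 2 `CCCCNC(=O)CC1CCc2cc(OC)c(OC)cc21`: 27.5%
Compound 3 `COc1cc2c(cc1OC)C(CC(=O)NCc1ccccc1)CC2`: 14.5%

Compound 3 stands lowest of the three numbers. Its nearest neighbour is compound 1, with a number 11.6 percentage points lower from compound 1 to compound 3 (beyond the scatter); compound 2 lies further, with a number 13 percentage points lower from compound 2 to compound 3 (beyond the scatter). Between compound 1 and compound 2 the difference is a number 1.4 percentage points higher from compound 1 to compound 2 (within the scatter), so the two alkyl amides cannot be told apart.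

Compound 4 `COc1cc2c(cc1OC)C(CC(=O)N1CCCCC1)CC2` carries piperidin-1-yl in place of benzylamino on a carbonyl carbon. Within the data shown here, no measured step makes this change, and none removes the amide hydrogen; the only steps that bear on it are those into compound 3, where a phenyl on the saturated chain carbon bound to the amide-type nitrogen went with a modest fall. Compound 4 has no six-membered aromatic ring in the amide part, and the two alkyl amides sit about the same. Among the measured compounds shown here, the expectation is therefore a rise back toward the level of compound 1 and compound 2, estimated as a number 8.5 percentage points higher from compound 3 to compound 4 (within the scatter), with the range kept wide because the tertiary amide has no precedent. For compound 4 the estimate is 23%, from 8% to 38%.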

Compound 4, a percentage reported as inhibition, in the whole organism at one dose (the size of the read-out at that dose, not a potency): 31.9%
For compound 4 the middle estimate is 8.9 percentage points below the measured one; measured number inside the range.
By their numbers in this assay, from the lowest: compound 3; then compounds 1, 2 and 4 (each within the scatter of the next).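

In this assay, piperidin-1-yl in place of benzylamino on the carbonyl carbon gives a number 17.4 percentage points higher from compound 3 to compound 4 (beyond the scatter), so the low number of compound 3 does not carry over to every group with a six-membered ring at this place. Against the two alkyl amides the same position gives a number 4.4 percentage points higher from compound 2 to compound 4 (within the scatter) and a number 5.8 percentage points higher from compound 1 to compound 4 (within the scatter), which places the piperidin-1-yl amide level with the butylamino and ethylamino amides and shows that losing the amide hydrogen, a change no earlier step covered, goes with no measurable fall in this read-out. No measured evidence is available on why benzylamino stands apart from the other three groups.

Benzylamino is the only group here that carries an aromatic ring, so one compound cannot show whether the low number follows the phenyl ring itself or its distance from the amide nitrogen, a question that phenylamino or 2-phenylethylamino would address. Going by these compounds, it also remains open whether the level shared by the other three extends to an open-chain diethylamino group or to a ring holding a second hetero atom, such as morpholin-4-yl.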